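Replacing the pyrrolidine amide with an acyl sulfonamide

A few compounds are considered here, and "the series" means these few. Any claim that something is new, unique, unknown or untested is made for them only; others in the source may bear on it.

The three measured compounds share one core and differ only in the group carried by the amide-type nitrogen. Compound 1 `Cc1cc(C)cc(S(=O)(=O)c2c(C(=O)N[C@@H]3CCNC3)[nH]c3ccc(Cl)cc23)c1` gives 37300 nM in an ADME assay on MT4 cells (Homo sapiens) for cytotoxicity, read by MTT assay, with a stated time of 5 days; on this read-out lower numbers stand for higher toxicity in this test and higher numbers for lower toxicity in this test. Compound 2 `Cc1cc(C)cc(S(=O)(=O)c2c(C(=O)N[C@@H]3CCN(CC(N)=O)C3)[nH]c3ccc(Cl)cc23)c1` gives 31000 nM, and compound 3 `Cc1cc(C)cc(S(=O)(=O)c2c(C(=O)NC3CN(CC(N)=O)C3)[nH]c3ccc(Cl)cc23)c1` gives 25500 nM. Compound 1 has the highest of the three numbers, but its steps to the others are small: a 1.2-fold lower number from compound 1 to compound 2 (0.08 log units; within the scatter) and a 1.5-fold lower number from compound 1 to compound 3 (0.17 log units; within the scatter), and between the other two a 1.2-fold lower number from compound 2 to compound 3 (0.08 log units; within the scatter). None of these steps leaves the scatter, so the three compounds cannot be ordered by toxicity on this evidence.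

Compound 4 `Cc1cc(C)cc(S(=O)(=O)c2c(C(=O)NS(=O)(=O)C3CC3)[nH]c3ccc(Cl)cc23)c1` is the new member. Relative to compound 1 its difference is cyclopropylsulfonyl in place of pyrrolidin-3-yl on an amide-type nitrogen. Among the measured compounds shown here, every measured step altered the same pyrrolidine region, whether by adding carbamoylmethyl or by shrinking the ring, and each stayed within the scatter, so there is no direct precedent for an acyl sulfonamide, but no measured change at this position has moved the number beyond the scatter. The step expected is therefore none beyond the scatter, which the estimate expresses as a 1.1-fold lower number from compound 1 to compound 4 (0.03 log units; within the scatter). Compound 4 is accordingly expected to give about 35000 nM, with a likely range from 14000 nM to 90000 nM.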

Compound 4, half-maximal cytotoxic concentration: 147000 nM
Estimate against measurement, compound 4: 4.2-fold (0.62 log units) below; the whole stated range lies below it.
By their numbers in this assay, from the lowest: compounds 3, 2 and 1 (each within the scatter of the next); then compound 4.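

In this assay, among the compounds shown here, no earlier change on this amide-type nitrogen had left the scatter, and cyclopropylsulfonyl is the first that does: a 3.9-fold higher number from compound 1 to compound 4 (0.60 log units; beyond the scatter) and a 4.7-fold higher number from compound 2 to compound 4 (0.68 log units; beyond the scatter) and also a 5.8-fold higher number from compound 3 to compound 4 (0.76 log units; beyond the scatter) all come with this one replacement. All three steps run the same way, with no compound shown going against them, so this position can shift the number towards lower toxicity in this test, although the earlier changes within the pyrrolidine and azetidine groups gave no sign of it. Nothing measured here accounts for the shift.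

With one acyl sulfonamide shown, it remains open whether the step belongs to the sulfonyl unit or to the cyclopropyl ring, which a methylsulfonyl or phenylsulfonyl group on the same nitrogen, or a cyclopropanecarbonyl group without sulfur, could help to separate. Going by these compounds, it is also open whether a simple cyclopropyl group on this nitrogen, or an open-chain amine in place of the ring amine, would give a number like that of compound 4 or stay with the other three.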